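A Single Chloro Group Removed: Expecting Compound 3

The source may hold more compounds than are shown below. What is called first, only, known or untested is meant among the compounds shown, and "the series" means these compounds.

Compound 2, `ClCc1ccccc1Cn1cnc2c(Cl)nc(Cl)nc21`, has been tested in a functional assay on NCI-H460 cells (Homo sapiens) for cytotoxicity, read by sulforhodamine B assay, with a stated time of 48 h (on this read-out lower numbers stand for higher toxicity in this test and higher numbers for lower toxicity in this test), yet for compound 2 the result is only a limit, > 100000 nM. This is the limit of > 100000 nM in this assay, at which 1 of the 2 values shown sits. Compound 1, `ClCc1ccc(Cn2cnc3c(Cl)ncnc32)cc1`, carries one chloro group on the shared core, and in this assay compound 1 gives 26900 nM. Compound 3, `ClCc1ccccc1Cn1cnc2c(Cl)ncnc21`, is not yet measured; it differs from compound 2 by hydrogen in place of chloro on an aromatic carbon. Among the measured compounds shown here, no measured step exists to set the size of this change. Since compound 1 reaches 26900 nM with a single chloro group, the step of an at least 2.0-fold lower number from compound 2 to compound 3 (0.30 log units; that floor lies within the scatter) is expected to move toward stronger cytotoxicity. Compound 3 is therefore estimated at 50000 nM, within 15000 nM to 150000 nM.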

Compound 3, concentration lethal to 50% of the cells: > 100000 nM
Compound 3 ended at the assay's limit (the forecaster's own chance of this, stated with the estimate: 35%); at least 2.0-fold (0.30 log units) between middle value and limit.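

Among the compounds shown here, compound 2 and compound 3 both end at a limit rather than a number, so no step between them can be read: the limit of > 100000 nM in this assay, at which 2 of the 3 values shown sit.

On these data alone, whether hydrogen in place of chloro on an aromatic carbon changes cytotoxicity at all, and by how much, stays open.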